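Swapping a furan ring for a cyclopentyl ring

A few compounds are considered here, and "the series" means these few. Any claim that something is new, unique, unknown or untested is made for them only; others in the source may bear on it.

Three measured compounds share one core and differ in the group on a saturated ring carbon. Compound 1 `CC1=C(C(=O)OC(C)C)C(C2CCCC2)N/C(=N/C#N)N1` carries a cyclopentyl group together with an isopropyl ester, and in an assay on cells for displacement of a labelled ligand from adenosine receptor A1 (Homo sapiens), with a stated time of 60 min, tested at 1 uM (on this read-out lower numbers stand for less inhibition and higher numbers for more inhibition at the one concentration tested (going by the name of the read-out)), compound 1 gives 3%. Compound 2 `CCOC(=O)C1=C(C)N/C(=N\C#N)NC1c1cccs1` carries thiophen-2-yl with an ethyl ester, and in this assay compound 2 gives 26%. Compound 3 `CCOC(=O)C1=C(C)N/C(=N\C#N)NC1c1ccco1` carries furan-2-yl with the same ethyl ester; in this assay compound 3 gives 27%, the highest of the three numbers, though its gap to compound 2 lies within the scatter. Among the compounds with values here, the only measured single change is a number 1 percentage points higher from compound 2 to compound 3 (within the scatter).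

Compound 4 `CCOC(=O)C1=C(C)N/C(=N\C#N)NC1C1CCCC1` is the next step: cyclopentyl in place of furan-2-yl on a saturated ring carbon. Within the data shown here, no measured step replaces a furan-2-yl by a cyclopentyl, so that earlier step says little here. Among the measured compounds shown here, compound 1, the one measured compound with a cyclopentyl group, sits well below compound 3, but it also bears a different ester. Compound 4 is therefore expected to move downward, by a number 19 percentage points lower from compound 3 to compound 4 (beyond the scatter). The estimate for compound 4 in this assay is 8%, within 0% to 25%.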

Compound 4, a percentage reported as inhibition, at one concentration (the size of the read-out at that concentration, not a potency): 11%
For compound 4 the middle estimate is 3 percentage points below the measured one, within the range that was stated.
By their numbers in this assay, from the lowest: compounds 1 and 4 (each within the scatter of the next); then compounds 2 and 3 (each within the scatter of the next).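

With the ethyl ester held fixed, the group on the saturated ring carbon does matter in this assay: putting cyclopentyl in place of furan-2-yl gives a number 16 percentage points lower from compound 3 to compound 4 (beyond the scatter) in this read-out, and putting it in place of thiophen-2-yl gives a number 15 percentage points lower from compound 2 to compound 4 (beyond the scatter) in the same read-out. Furan-2-yl and cyclopentyl have the same count of heavy atoms, so that count alone does not account for the drop. With cyclopentyl kept, going from the isopropyl ester to the ethyl ester gives a number 8 percentage points higher from compound 1 to compound 4 (within the scatter) and so stays within the scatter, which ties the low number of compound 1 to the cyclopentyl group more than to its ester.

Nothing available explains why the aromatic rings and cyclopentyl differ here. Going by these compounds, it also remains open how a phenyl ring or an open chain such as n-butyl would behave on this carbon.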